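Notes on 6-fluoropyridin-3-yl in place of 4-fluorophenyl

The source may report more compounds than this note shows. Statements on the series, on what has been measured and on what is new or still open speak of the compounds shown alone.

compound 1 `COc1ccc(C(=O)/C=C/c2ccccc2-c2ccc(F)nc2)cc1`: 13000 nM
compound 2 `COc1ccc(C(=O)/C=C/c2ccccc2-c2ccc(F)nc2)cc1OC`: 17000 nM
compound 3 `COc1ccc(C(=O)/C=C/c2ccccc2-c2ccc(F)cc2)cc1O`: 750 nM
compound 4 `COc1ccc(C(=O)/C=C/c2ccccc2-c2ccc(F)nc2)cc1O`: not yet measured

In a functional assay on CNE-2 cells (Homo sapiens) for antiproliferative activity, read by sulforhodamine B assay, with a stated time of 48 h (a lower number here means a stronger inhibitor, a higher number a weaker inhibitor), compound 3 gives 750 nM, the lowest of the three numbers and beyond the scatter from both compound 1 and compound 2. The change to compound 4 is 6-fluoropyridin-3-yl in place of 4-fluorophenyl on an aromatic carbon, 6-fluoropyridin-3-yl in place of 4-fluorophenyl, ortho to a large group.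

Going by the values given here, the only measured single-place step, a 1.3-fold higher number from compound 1 to compound 2 (0.12 log units; within the scatter), is methoxy in place of hydrogen on an aromatic carbon. Among the compounds with values here, it lies within the scatter and does not involve this swap, so no measured pair isolates the swap. Compound 1 and compound 2 carry the entering 6-fluoropyridin-3-yl but lack the hydroxy group shared by compound 3 and compound 4. Their gap to compound 3 therefore mixes two differences, and the data do not divide it.

A rise in the number is expected, of uncertain size, with compound 3 at 750 nM as the lower anchor and compound 1 at 13000 nM as the upper guide. The expected change is a 2.7-fold higher number from compound 3 to compound 4 (0.43 log units; beyond the scatter). For compound 4 the estimated value is 2000 nM, with an expected range of 500 nM to 9000 nM.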

Compound 4, half-maximal inhibitory concentration: 2100 nM
The estimate for compound 4 lay 1.1-fold (0.02 log units) below the measured number; the measured number falls inside the stated range.
By their numbers in this assay, from the lowest: compound 3; then compound 4; then compounds 1 and 2 (each within the scatter of the next).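

With the hydroxy group held constant, the swap to 6-fluoropyridin-3-yl in place of 4-fluorophenyl, on an aromatic carbon ortho to a large group, now has a measured pair of its own in this assay and gives a 2.8-fold higher number from compound 3 to compound 4 (0.45 log units; beyond the scatter) as a step beyond the scatter. Going by these compounds alone, with 6-fluoropyridin-3-yl held constant, hydroxy in place of hydrogen gives a 6.2-fold lower number from compound 1 to compound 4 (0.79 log units; beyond the scatter) and hydrogen in place of methyl on an oxygen gives an 8.1-fold lower number from compound 2 to compound 4 (0.91 log units; beyond the scatter) so that the two differences mixed in the earlier compounds can now be read separately, and both pairs favour the free hydroxy group. Nothing shown gives a reason for any of these steps.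

From the compounds shown here alone, the swap is read in one pair only, with the hydroxy group present, so its size without that group stays open. Going by these compounds, it is also open whether an amine or a carboxylic acid in place of the hydroxy group would keep the lower number, and whether chlorine in place of fluorine on the 6-fluoropyridin-3-yl would change the step.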